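This account rests on a few compounds, and the source may have more. Where it says the series, first, only, none or still open, it means among the compounds named here.

Compound 1, `Nc1nc(NC2CCCCC2)c2ncn(/C=C3/CC3(CO)CO)c2n1`: "not determined" (no result reported) in an ADME assay on MOLT-3 cells (Homo sapiens) for cytotoxicity, with a stated time of 7 days; on this read-out lower numbers stand for higher toxicity in this test and higher numbers for lower toxicity in this test
Compound 2, `CCCCNc1nc(N)nc2c1ncn2/C=C1/CC1(CO)CO`: > 20000 nM
Compound 3, `Nc1nc(OCC(F)(F)F)c2ncn(/C=C3/CC3(CO)CO)c2n1`: > 20000 nM

The three compounds share one core and differ only in the group attached to it. In this assay compound 2 gives no number, only a limit of the test, > 20000 nM. Compound 3 likewise reaches only the limit, > 20000 nM. Compound 1 has no reported result, "not determined" (no result reported). Compound 2 therefore stands at the limit of > 20000 nM in this assay, at which 2 of the 3 values shown sit, with the one other reported entry sitting at the same point, so its place among the numbers is known only as a limit.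

Going by the values given here, the single measured step, a step that the two limits leave unreadable from compound 2 to compound 3, cannot be read, since both of its ends are limits rather than numbers. The step towards compound 4, `CCOc1nc(N)nc2c1ncn2/C=C1/CC1(CO)CO`, is ethoxy in place of butylamino on an aromatic carbon. This change resembles the step to compound 3 in taking away the butylamino group and bringing in an oxygen-linked group, yet that step gives no usable size, so no direction or size beyond the scatter can be taken from it.

The expectation is that compound 4 also reaches only the limit, with a step of a number no higher from compound 2 to compound 4 (the limit leaves the size open) from compound 2. Compound 4 is estimated at 20000 nM, within a range from 8000 nM to 60000 nM.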

Compound 4, half-maximal cytotoxic concentration: > 20000 nM
Compound 4 ended at the assay's limit (the forecaster's own chance of this, stated with the estimate: 85%); the middle value lies on the limit itself.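

The steps linking compound 4 to compound 2 and compound 3 cannot be read, since all three compounds give only a limit, not a number, in this assay: the limit of > 20000 nM in this assay, at which 3 of the 4 values shown sit.

The compounds shown leave open how far apart compound 2, compound 3 and compound 4 truly lie, and whether any group at this place on the shared core gives a measurable number.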